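The source may hold more compounds than are shown below. What is called first, only, known or untested is meant among the compounds shown, and "the series" means these compounds.

In a functional assay on MCF7 cells (Homo sapiens) (a higher number here means a weaker inhibitor of growth, a lower number a stronger inhibitor of growth), compound 1 `O=S(=O)(/C=C/c1ccc(F)cc1)Cc1ccc(Nc2ncnc3ccccc23)cc1` gives 16000 nM. Compound 2 `O=S(=O)(/C=C/c1ccc(Cl)c(Cl)c1)Cc1ccc(Nc2ncnc3ccccc23)cc1` gives 28000 nM. Compound 3 `O=S(=O)(/C=C/c1ccc(C(F)(F)F)cc1F)Cc1ccc(Nc2ncnc3ccccc23)cc1` gives 100000 nM.

Compound 1 has the lowest of the three numbers, but a 1.8-fold higher number from compound 1 to compound 2 (0.24 log units; within the scatter), so compounds 1 and 2 cannot be separated; only a 6.3-fold higher number from compound 1 to compound 3 (0.80 log units; beyond the scatter) shows a clear loss. Compound 4 `O=S(=O)(/C=C/c1ccc(O)cc1)Cc1ccc(Nc2ncnc3ccccc23)cc1` differs from compound 1 in one place: hydroxy in place of fluoro on an aromatic carbon. For the measured compounds named here, no measured step brings in a hydroxy; the two measured steps change the same group on a double-bonded chain carbon, with halogens or trifluoromethyl entering, and they run from no change to a modest weakening. A step near the scatter is therefore expected, a 1.1-fold lower number from compound 1 to compound 4 (0.03 log units; within the scatter), with wide uncertainty. Compound 4 is estimated at 15000 nM, in the range 5000 nM to 50000 nM.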

Compound 4, concentration for 50% growth inhibition: 100000 nM
Compound 4: the middle estimate sits 6.7-fold (0.82 log units) below what was measured, outside the stated range (above it).
By their numbers in this assay, from the lowest: compounds 1 and 2 (each within the scatter of the next); then compounds 3 and 4 (each within the scatter of the next).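

In this assay, replacing one atom at this position matters: hydroxy in place of fluoro gives a 6.3-fold higher number from compound 1 to compound 4 (0.80 log units; beyond the scatter). The 4-hydroxyphenyl group also gives a 3.6-fold higher number from compound 2 to compound 4 (0.55 log units; beyond the scatter), whereas no change at the digits printed from compound 3 to compound 4 (within the scatter) leaves it inseparable from 2-fluoro-4-(trifluoromethyl)phenyl. A weakening on this ring therefore does not require a halogen or trifluoromethyl group to enter. Nothing available explains why hydroxy weakens growth inhibition relative to fluoro. As far as these compounds go, whether a methoxy group, an amine or a carboxylic acid at this position would behave more like hydroxy or like fluoro remains open.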